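A few compounds are considered here, and "the series" means these few. Any claim that something is new, unique, unknown or untested is made for them only; others in the source may bear on it.

Measured in a functional assay on A549 cells (Homo sapiens) for cytotoxicity, read by MTT assay, with a stated time of 24 h; on this read-out lower numbers stand for stronger inhibition and higher numbers for weaker inhibition:
Compound 1 `CCOC(=O)N1CCC(=NNC(=O)c2ccc(F)cc2)CC1`: > 400000 nM
Compound 2 `O=C(NN=C1CC(c2ccccc2)NC(c2ccccc2)C1)c1ccc(F)cc1`: > 400000 nM

Compound 1 gives a limit of the assay and not a number. Compound 2 likewise stands only at a limit, > 400000 nM, so no exact half-maximal inhibitory concentration is known for it. The two compounds share one position: the limit of > 400000 nM in this assay, at which 2 of the 2 values shown sit.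

Compound 3 `O=C(NN=C1CC(c2ccccc2)NC(c2ccccc2)C1)c1ccc([N+](=O)[O-])cc1` keeps the core of compound 2 but carries nitro in place of fluoro on an aromatic carbon, para to a large group, which turns 4-fluorophenyl into 4-nitrophenyl: nitro in place of fluoro on an aromatic carbon. Among the measured compounds shown here, no measured step shows what such a change does in this assay, so no shift beyond the scatter is expected in either direction. The estimated at least 1.1-fold lower number from compound 2 to compound 3 (0.05 log units; that floor lies within the scatter) is expected to remain small. For compound 3 the expected value is 350000 nM, with an estimated range from 120000 nM to 800000 nM.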

Compound 3, half-maximal inhibitory concentration: > 400000 nM
Compound 3 was reported as a limit; the forecaster's own chance of this, stated with the estimate: 60%; middle value at least 1.1-fold (0.05 log units) away from the limit.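

In this assay compound 3 gives > 400000 nM, again a limit of the assay and not a number. Among the compounds shown here, no step from compound 2 to compound 3 can be read, and the series shows one position only: the limit of > 400000 nM in this assay, at which 3 of the 3 values shown sit. The compounds shown leave open whether nitro in place of fluoro changes the half-maximal inhibitory concentration at all.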